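A few compounds are considered here, and "the series" means these few. Any claim that something is new, unique, unknown or untested is made for them only; others in the source may bear on it.

In a functional assay on PC-3 cells (Homo sapiens) for cytotoxicity, read by WST assay, with a stated time of 72 h (a lower number here means a stronger inhibitor, a higher number a weaker inhibitor), compound 1 `O=C1Nc2c(ccc(F)c2F)C1(c1ccc(O)cc1)c1cccnc1` reads > 1000 nM, which is a limit of the assay and not a number. Going by the values given here, compound 2 `O=C1Nc2c(ccc(F)c2F)C1(c1ccc(O)cc1)C1CCCC1` gives 8.2 nM, so far the only true number. Compound 3 `O=C1Nc2c(ccc(F)c2F)C1(c1ccc(O)cc1)C1CCCCCC1` carries cycloheptyl in place of cyclopentyl on a saturated ring carbon. Among the compounds with values here, the one measured step, an at least 120-fold lower number from compound 1 to compound 2 (2.08 log units; beyond the scatter), is large, but it removed pyridin-3-yl, whereas here one ring of carbon only replaces another. A much smaller change is therefore expected in this assay, probably a slightly higher number. The estimate for compound 3 is 15 nM, within a range of 4 nM to 60 nM. This estimate means an expected 1.8-fold higher number from compound 2 to compound 3 (0.26 log units; within the scatter).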

Compound 3, half-maximal inhibitory concentration: 12 nM
Estimate against measurement, compound 3: 1.3-fold (0.10 log units) above, within the range that was stated.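

In this assay, cycloheptyl in place of cyclopentyl gives a 1.5-fold higher number from compound 2 to compound 3 (0.17 log units; within the scatter) and so these two carbon-only rings of different size read alike at this position. Cycloheptyl in place of pyridin-3-yl gives an at least 83-fold lower number from compound 1 to compound 3 (1.92 log units; beyond the scatter) and so the large gap first seen with cyclopentyl is not tied to that one ring. This second step rests on a limit, not a true number: the limit of > 1000 nM in this assay, at which 1 of the 3 values shown sits.

Still open, as far as these compounds go, is how a smaller carbon ring such as cyclopropyl, an open chain such as isopropyl, or an amine-bearing ring such as piperidine would read here. Phenyl, which lacks the ring nitrogen of pyridin-3-yl, also remains open.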